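This account rests on a few compounds, and the source may have more. Where it says the series, first, only, none or still open, it means among the compounds named here.

The measured compounds:
- compound 1, `O=S(=O)(Nc1ccc(-c2nc3ccccc3o2)cc1)c1cccc(Cl)c1`: 54000 nM
- compound 2, `COc1ccccc1S(=O)(=O)Nc1ccc(-c2nc3ccccc3o2)cc1`: > 100000 nM

In an assay on cells for inhibition of HSP60/HSP10 (Homo sapiens), with a stated time of 60 min (on this read-out higher numbers stand for weaker inhibition and lower numbers for stronger inhibition), compound 2 gives > 100000 nM, and this is a limit of the assay rather than a measured number (the limit of > 100000 nM in this assay, at which 1 of the 2 values shown sits). Within the data shown here, compound 1 is the only other compound measured, and in this assay compound 1 gives 54000 nM. Among the measured compounds shown here, the single step known between them is an at least 1.8-fold higher number from compound 1 to compound 2 (0.26 log units; that floor lies within the scatter), and its floor lies within the usual scatter, so the two compounds cannot be told apart with confidence.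

Compound 3, `O=S(=O)(Nc1ccc(-c2nc3ccccc3o2)cc1)c1ccc(F)cc1`, differs from compound 2 by 4-fluorophenyl in place of 2-methoxyphenyl on a sulfonyl sulfur. For the measured compounds named here, the only measured step that bears on this change is the one just described, which went in the opposite direction, from a chlorine-bearing phenyl to the methoxyphenyl, and was small. Reversing to another halogen-bearing phenyl therefore suggests a number near the one seen for compound 1, with a step of an at least 1.4-fold lower number from compound 2 to compound 3 (0.15 log units; that floor lies within the scatter) expected. The estimate for compound 3 is 70000 nM, with a range from 25000 nM to 200000 nM, and a substantial chance that only a limit is reported.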

Compound 3, half-maximal inhibitory concentration: 73000 nM
Beside the measured number, compound 3's estimate is 1.0-fold (0.02 log units) below it; low and high end bracket the measured number.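

Compound 3 gives a second real number in this assay for a halogen-bearing phenyl on the sulfonyl sulfur, and the change from 3-chlorophenyl to 4-fluorophenyl leaves the two compounds impossible to tell apart: a 1.4-fold higher number from compound 1 to compound 3 (0.13 log units; within the scatter). Swapping both the halogen and its place on the ring therefore shows no clear effect on this read-out, which the earlier pair could not show. The change from 2-methoxyphenyl to 4-fluorophenyl is only a floor, and that floor does not separate the two groups, so compound 2 remains a limit rather than a number in this comparison, an at least 1.3-fold lower number from compound 2 to compound 3 (0.13 log units; that floor lies within the scatter), and the reading rests on this: the limit of > 100000 nM in this assay, at which 1 of the 3 values shown sits.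

From the compounds shown here alone, the 3-chlorophenyl and 4-fluorophenyl groups differ in halogen and in its place at the same time, so the contribution of each of these two features stays open. Also open, going by these compounds, is whether a phenyl ring carrying an amine or a carboxylic acid, or a longer chain on the sulfonyl sulfur in place of the phenyl ring, would shift the number beyond the usual scatter.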